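The source may hold more compounds than are shown below. What is called first, only, known or untested is meant among the compounds shown, and "the series" means these compounds.

Compound 2 `O=C(CCSc1nc2cc(Cl)ccc2o1)N1CCCCC1` gives the highest number among the three measured compounds in an ADME assay on microsomes from liver (Homo sapiens) for metabolic stability, read by LC-MS, using NADPH, with a stated time of 45 min, tested at 0.5 uM (a lower number here means slower removal, a higher number faster removal of the compound), namely 10.7 mL/min/g. Compound 3 `Cc1ccc2oc(SCCC(=O)N3CCCC3)nc2c1` stands nearest to it, giving 9.3 mL/min/g in this assay, a gap that lies within the scatter. Compound 1 `CS(=O)(=O)C1CCN(C(=O)CCSc2nc3cc(Cl)ccc3o2)CC1`, the furthest, gives 0.5 mL/min/g in this assay. Within the data shown here, the one measured step that changes the amide ring, a 21-fold higher number from compound 1 to compound 2 (1.33 log units; beyond the scatter), shows that a substitution on that ring can move the number a long way.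

Compound 4 `CN1CCN(C(=O)CCSc2nc3cc(Cl)ccc3o2)CC1` is the next compound to be measured. It differs from compound 2 by a single change: 4-methylpiperazin-1-yl in place of piperidin-1-yl on a carbonyl carbon. Among the measured compounds shown here, the amide ring is again the place of change, so the step from compound 1 to compound 2 is the one that bears on it, though the entering group is not the one that step tested. On that basis a lower number is expected for compound 4 in this assay, of moderate size, a 2.1-fold lower number from compound 2 to compound 4 (0.33 log units; beyond the scatter). Compound 4 is thus estimated at 5 mL/min/g, with a range from 2 mL/min/g to 12 mL/min/g.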

Compound 4, intrinsic clearance in a liver preparation (reported as CLH), per the amount of preparation that the assay uses: 1.5 mL/min/g
The estimate for compound 4 lay 3.3-fold (0.52 log units) above the measured number; the whole stated range lies above it.
By their numbers in this assay, from the lowest: compound 1; then compound 4; then compounds 3 and 2 (each within the scatter of the next).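

The change to 4-methylpiperazin-1-yl in place of piperidin-1-yl on a carbonyl carbon gives a 7.1-fold lower number from compound 2 to compound 4 (0.85 log units; beyond the scatter) in this assay, so the number at this place falls with a second entering group, one that differs from methylsulfonyl on a saturated ring carbon. Among the compounds shown, piperidin-1-yl without a substituent therefore stands with the high number, while compound 4 gives 1.5 mL/min/g and compound 1 gives 0.5 mL/min/g. No measurement is available here that would account for the size of this step.

Going by these compounds, it remains open whether the step goes with the second ring nitrogen or with its methyl, which piperazin-1-yl without the methyl could separate. On these data alone, it is also open whether morpholin-4-yl, with a ring oxygen, or an acetyl on that nitrogen would give a similar number.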